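Moving the chlorine on the urea phenyl: a paired step

The source may report more compounds than this note shows. Statements on the series, on what has been measured and on what is new or still open speak of the compounds shown alone.

Measured compounds:
compound 1 `CN(C)CCNc1nc(-c2ccc(NC(=O)Nc3ccc(Cl)cc3)cc2)nc2ccsc12`: 95 nM
compound 2 `CN(C)CCNc1nc(-c2ccc(NC(=O)Nc3ccccc3Cl)cc2)nc2ccsc12`: 310 nM
compound 3 `CCN(CC)CCNc1nc(-c2ccc(NC(=O)Nc3ccc(Cl)cc3)cc2)nc2c(Cl)c(Cl)sc12`: 430 nM

All three compounds were tested in a functional assay on HT-29 cells (Homo sapiens) for cytotoxicity, read by MTT assay, with a stated time of 72 h; on this read-out lower numbers stand for stronger inhibition and higher numbers for weaker inhibition. Compound 1 and compound 2 share one core and differ only in the chlorophenyl group on the urea: 2-chlorophenyl in place of 4-chlorophenyl on an amide-type nitrogen. That change produced a 3.3-fold higher number from compound 1 to compound 2 (0.51 log units; beyond the scatter).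

Compound 3 carries a different core, and the difference between the two cores is not broken down here. Compound 4 `CCN(CC)CCNc1nc(-c2ccc(NC(=O)Nc3ccccc3Cl)cc2)nc2c(Cl)c(Cl)sc12` has not yet been measured. It relates to compound 3 in the same way that compound 2 relates to compound 1: 2-chlorophenyl in place of 4-chlorophenyl on an amide-type nitrogen. The place of the change reads the same in both pairs, so this is the same change made on a second core.

Among the compounds with values here, with only one earlier example of this change to go on, the expectation is that compound 4 will follow it, so a step of about a 3.3-fold higher number from compound 3 to compound 4 (0.51 log units; beyond the scatter) in this assay is estimated, resting on the step from compound 1 to compound 2. On that basis compound 4 is expected to give about 1400 nM, most likely between 500 nM and 4000 nM.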

Compound 4, half-maximal inhibitory concentration: 550 nM
Compound 4: middle estimate off by 2.5-fold (0.41 log units), on the high side; measured number inside the range.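

On the second core, 2-chlorophenyl in place of 4-chlorophenyl on the amide-type nitrogen gave a 1.3-fold higher number from compound 3 to compound 4 (0.11 log units; within the scatter) in this assay, a step too small to be told apart from repeat-measurement noise. Set beside the step on the first core, this result does not differ from it by more than the scatter of two such steps allows: the same change on two cores in this assay, a 3.3-fold higher number (0.51 log units; beyond the scatter) from compound 1 to compound 2 and a 1.3-fold higher number (0.11 log units; within the scatter) from compound 3 to compound 4, 2.6-fold (0.41 log units) apart, within the scatter of two such steps The change may therefore carry over from one core to the other at a similar size, or it may have little effect on the second core, and two pairs of compounds cannot separate these readings or explain either one.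

From the compounds shown here alone, compounds 1 and 3 differ in more than one place, so the separate contribution of each difference between them remains unknown. Also open, going by these compounds, is how the series would respond to an unsubstituted phenyl or a pyridine ring in place of the chlorophenyl group, or to a morpholine in place of the dialkylamino group on the side chain.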